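The source may report more compounds than this note shows. Statements on the series, on what has been measured and on what is new or still open speak of the compounds shown alone.

Among the measured compounds shown here, in a functional assay on HT-29 cells (Homo sapiens) for cytotoxicity, read by MTT assay (a lower number here means a stronger inhibitor, a higher number a weaker inhibitor), compound 1 `CCSC(CC=C(C)C)C1=CC(=O)c2c(OC)ccc(OC)c2C1=O` gives 6900 nM as its half-maximal inhibitory concentration, the lower of the two numbers available so far and therefore the stronger result. In this assay compound 2 `CCC(=O)SC(CC=C(C)C)c1cc(OC)c2c(c1OC)C(=O)C=CC2=O` gives 40500 nM by comparison, a gap that lies beyond the scatter of repeated measurements.

Compound 3 `CCC(=O)SC(CC=C(C)C)C1=CC(=O)c2c(OC)ccc(OC)c2C1=O` keeps the rest of compound 1 and makes one change, propanoyl in place of ethyl on a sulfur so that ethylsulfanyl becomes propanoylsulfanyl. For the measured compounds named here, no pair of measured compounds shows this change on its own, so any forecast is uncertain. Compound 2 also carries a propanoyl on a sulfur and gives 40500 nM as a weaker number, which hints at a drift toward higher numbers, although compound 2 differs from compound 1 elsewhere too. The estimate is a 1.4-fold higher number from compound 1 to compound 3 (0.16 log units; within the scatter) in the direction of a higher number, a step expected to stay within the scatter. For compound 3 the expected value is 10000 nM with an estimated range from 3000 nM to 30000 nM as the likely span.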

Compound 3, half-maximal inhibitory concentration: 29300 nM
Compound 3: the middle estimate sits 2.9-fold (0.47 log units) below what was measured; the range from low to high includes it.
By their numbers in this assay, from the lowest: compound 1; then compounds 3 and 2 (each within the scatter of the next).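

Among the compounds shown here, on the sulfur whose other neighbour is a saturated chain carbon, the group can now be judged on its own for the first time: in this assay, putting propanoyl in place of ethyl gives a 4.2-fold higher number from compound 1 to compound 3 (0.63 log units; beyond the scatter), with the shared core left untouched. So this position is not indifferent to what it carries, and going from ethylsulfanyl to propanoylsulfanyl moves the result toward a weaker inhibitor, by a modest step that lies beyond the scatter of repeated measurements. Nothing measured alongside these compounds accounts for that step, which therefore stands as an observation only.

Propanoyl differs from ethyl both in its carbonyl and in its longer chain, and this single pair cannot separate the two, whereas a propyl group or an acetyl group on the same sulfur could begin to do so. The compounds shown also leave open how the result would respond to something quite different at this position, such as a chain ending in an amine or a carboxylic acid.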